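Phenyl in Place of Methyl on a Shared Core

The source may hold more compounds than are shown below. What is called first, only, known or untested is meant among the compounds shown, and "the series" means these compounds.

Of the compounds shown here, two have so far been measured in a functional assay on the whole organism (liver, strain Wistar) for inhibition, with Rattus norvegicus as the target, with a stated time of 3 h, at a dose of 3 mg/kg by the oral route; a higher number here means more inhibition at the dose given (going by the name of the read-out), a lower number less inhibition. Compound 1 `Cc1c(C)c(C)[n+]([O-])c(Cl)c1-c1noc(-c2cc(O)c(O)c([N+](=O)[O-])c2)n1` gives 7.9% in this assay, and compound 2 `Cc1cc(C(F)(F)F)c(-c2noc(-c3cc(O)c(O)c([N+](=O)[O-])c3)n2)c(C)[n+]1[O-]` gives 1.3%, a gap that lies within the usual scatter, so the two cannot be told apart on these numbers. Compound 3 `Cc1c(-c2noc(-c3cc(O)c(O)c([N+](=O)[O-])c3)n2)c(C(F)(F)F)cc(-c2ccccc2)[n+]1[O-]` differs from compound 2 in one place: phenyl in place of methyl on an aromatic carbon. Among the compounds with values here, no measured pair shows what this change does here, so no direction can be read off. The step is expected to be a number 3.7 percentage points higher from compound 2 to compound 3 (within the scatter), nothing beyond the scatter. Compound 3 is expected to give about 5%, between -10% and 25%.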

Compound 3, a percentage reported as inhibition, in the whole organism at one dose (the size of the read-out at that dose, not a potency): 24.3%
Beside the measured number, compound 3's estimate is 19.3 percentage points below it; the range from low to high includes it.
By their numbers in this assay, from the lowest: compounds 2 and 1 (each within the scatter of the next); then compound 3.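

Phenyl in place of methyl gives a number 23 percentage points higher from compound 2 to compound 3 (beyond the scatter) in this assay, so on this core the aromatic carbon next to the ring nitrogen can carry a far larger group without losing inhibition at this dose. Within the data shown here, this rests on a single pair, which is the only measured change here that reaches beyond the scatter. No measurement at hand explains the step.

From the compounds shown here alone, whether a cyclohexyl ring, a longer alkyl chain or an amine in this place would give a similar step stays open. So does whether phenyl would act the same way on the core of compound 1.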